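Extending the Amine Chain of Compound 1

This account rests on a few compounds, and the source may have more. Where it says the series, first, only, none or still open, it means among the compounds named here.

Compound 1 `CCn1c(=O)n(C(=O)NCCN2CCN(C)CC2)c2ccccc21` has been tested in a functional assay for agonist activity at 5-hydroxytryptamine receptor 4 (Cavia porcellus); a higher number here means a larger maximal response, a lower number a smaller maximal response. In this assay compound 1 gives < 0.3, a limit of the assay rather than a number (the limit of < 0.3 in this assay, at which 1 of the 2 values shown sits). Compound 2 `CN1CCN(CCNC(=O)n2c(=O)[nH]c3ccccc32)CC1` gives 0.35 in this assay. For the measured compounds named here, the single measured step, a number at least 0.050 higher from compound 1 to compound 2 (that floor lies within the scatter), concerns hydrogen in place of ethyl on an aromatic nitrogen, a different part of the shared core from the change considered here.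

Compound 3 `CCCCN1CCN(CCNC(=O)n2c(=O)n(CC)c3ccccc32)CC1` differs from compound 1 as follows: propyl in place of hydrogen on a saturated chain carbon bound to an amine nitrogen in a ring. Going by the values given here, no measured step touches this position, so the step from compound 1 to compound 2 gives no direct guide to it. Compound 1 sits at a limit of the assay, and there is nothing in the measured pair pointing to a gain from this change. The expected step is a step that the limit leaves unreadable from compound 1 to compound 3, none beyond the scatter. Compound 3 is estimated at 0.25, with a range from 0.1 to 0.4.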

Compound 3, intrinsic activity: the largest response reached, as a fraction of the reference agonist's: < 0.3
Compound 3: no number, only a limit (the forecaster's own chance of this, stated with the estimate: 60%); the middle value lies beyond the limit too.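

For the compounds shown here, compound 1 and compound 3 both stand at a limit rather than a number, so no step between them can be read: the limit of < 0.3 in this assay, at which 2 of the 3 values shown sit. The compounds shown leave open whether propyl in place of hydrogen at this position changes the maximal response at all.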